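This account rests on a few compounds, and the source may have more. Where it says the series, first, only, none or still open, it means among the compounds named here.

Among the numbers so far, compound 3 `CCCSc1nc(N/N=C/c2c[nH]c3ccccc23)c2nnn(Cc3ccccc3)c2n1` stands lowest, with 9010 nM in a functional assay on MCF7 cells (Homo sapiens) for antiproliferative activity, read by MTT assay, with a stated time of 72 h; on this read-out lower numbers stand for stronger inhibition and higher numbers for weaker inhibition. Compound 2 `CCCSc1nc(N/N=C/c2ccc([N+](=O)[O-])cc2)c2nnn(Cc3ccccc3)c2n1` gives 11000 nM in this assay, and a 1.2-fold lower number from compound 2 to compound 3 (0.09 log units; within the scatter) lies within the scatter. Compound 1 `CCCSc1nc(N/N=C/c2ccc(Cl)cc2)c2nnn(Cc3ccccc3)c2n1` reaches only a limit, > 64000 nM, as the limit of > 64000 nM in this assay, at which 1 of the 3 values shown sits, records. Compound 4 `CCCSc1nc(N/N=C/c2c(O)ccc3ccccc23)c2nnn(Cc3ccccc3)c2n1` differs from compound 3 in one place: 2-hydroxynaphthalen-1-yl in place of 1H-indol-3-yl on a carbon with a double bond to nitrogen. Among the compounds with values here, the only measured steps at this position are an at least 7.1-fold lower number from compound 1 to compound 3 (0.85 log units; beyond the scatter) and an at least 5.8-fold lower number from compound 1 to compound 2 (0.76 log units; beyond the scatter), both starting from the limit of compound 1, and a 1.2-fold lower number from compound 2 to compound 3 (0.09 log units; within the scatter), which is within the scatter. None of them swaps in a 2-hydroxynaphthalen-1-yl, so the step to compound 4 is expected to be a 1.1-fold lower number from compound 3 to compound 4 (0.05 log units; within the scatter), no change beyond the scatter. Compound 4 is therefore estimated at 8000 nM, between 2500 nM and 30000 nM.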

Compound 4, half-maximal inhibitory concentration: 6400 nM
Compound 4: middle estimate off by 1.3-fold (0.10 log units), on the high side, within the range that was stated.
By their numbers in this assay, from the lowest: compounds 4, 3 and 2 (each within the scatter of the next). At a limit, above all of these: compound 1.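

At the carbon with a double bond to nitrogen, 2-hydroxynaphthalen-1-yl does not separate from the two groups already there, with a 1.4-fold lower number from compound 3 to compound 4 (0.15 log units; within the scatter) and a 1.7-fold lower number from compound 2 to compound 4 (0.24 log units; within the scatter), so three different groups now sit within the scatter of one another. Only the 4-chlorophenyl of compound 1 stands apart, with an at least 10-fold lower number from compound 1 to compound 4 (1.00 log units; beyond the scatter), a step that starts from a limit. Compound 1 remains the one compound at a limit: the limit of > 64000 nM in this assay, at which 1 of the 4 values shown sits.

The compounds shown leave open what a dimethylamino group or a carboxylic acid in place of the nitro of compound 2 would give. They also leave open whether a naphthalen-1-yl without the hydroxyl would stay level with compound 4.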